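Moving the Chlorine Around the Phenyl Ring

The source may hold more compounds than are shown below. What is called first, only, known or untested is meant among the compounds shown, and "the series" means these compounds.

Of the compounds shown here, three sharing one core have been tested in a functional assay, with a stated time of 20 min; a higher number here means a weaker inhibitor, a lower number a stronger inhibitor. Compound 1 `CCOC(=O)c1cnn(-c2nc(-c3ccccc3O)c(C#N)c(=O)n2C)c1N` gives 48 ug/mL. Compound 2 `CCOC(=O)c1cnn(-c2nc(-c3ccco3)c(C#N)c(=O)n2C)c1N` gives 91 ug/mL, and compound 3 `CCOC(=O)c1cnn(-c2nc(-c3ccccc3Cl)c(C#N)c(=O)n2C)c1N` gives 78 ug/mL. Among these three numbers compound 3 stands second highest; its nearest neighbour is compound 2 and its furthest is compound 1, and both gaps, a 1.2-fold lower number from compound 2 to compound 3 (0.07 log units; within the scatter) and a 1.6-fold higher number from compound 1 to compound 3 (0.21 log units; within the scatter), lie within the scatter of the measurement. Likewise a 1.9-fold higher number from compound 1 to compound 2 (0.28 log units; within the scatter) stays within the scatter, so the three aryl groups tried so far have not separated the compounds in this assay.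

Compound 4 `CCOC(=O)c1cnn(-c2nc(-c3ccc(Cl)cc3)c(C#N)c(=O)n2C)c1N` has not yet been measured. It differs from compound 3 in one place: 4-chlorophenyl in place of 2-chlorophenyl on an aromatic carbon. Within the data shown here, no measured pair shows this particular exchange of one chlorophenyl for the other. Among the measured compounds shown here, the only steps that bear on it are the exchanges of the whole aryl group, and each of those stayed within the scatter. The expected step in this assay is therefore none beyond the scatter, estimated as a 1.0-fold higher number from compound 3 to compound 4 (0.01 log units; within the scatter). Compound 4 is expected to give about 80 ug/mL in this assay, most likely between 35 ug/mL and 180 ug/mL.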

Compound 4, half-maximal inhibitory concentration: 64 ug/mL
For compound 4 the middle estimate is 1.3-fold (0.10 log units) above the measured one; the range from low to high includes it.
By their numbers in this assay, from the lowest: compounds 1, 4, 3 and 2 (each within the scatter of the next).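

In this assay, among these compounds, compound 3 and compound 4 offer the first direct comparison of where the chlorine sits on this phenyl ring, and the exchange of 2-chlorophenyl for 4-chlorophenyl gives a step within the scatter (a 1.2-fold lower number from compound 3 to compound 4 (0.09 log units; within the scatter)). The 4-chlorophenyl group also stays within the scatter of the two other aryl groups on this aromatic carbon (a 1.4-fold lower number from compound 2 to compound 4 (0.15 log units; within the scatter); a 1.3-fold higher number from compound 1 to compound 4 (0.12 log units; within the scatter)), so none of the four groups tried at this position can yet be told apart from the others. No supporting measurement bears on why moving the chlorine leaves the number within the scatter.

As far as these compounds go, all four groups are aromatic rings, so it remains open whether something of another kind at this position, such as an amine or a longer alkyl chain, would give a step beyond the scatter. From the compounds shown here alone, it is equally open whether a carboxylic acid on the phenyl ring, in place of the chlorine, would separate itself from these compounds.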